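The source may hold more compounds than are shown below. What is called first, only, known or untested is meant among the compounds shown, and "the series" means these compounds.

Of the compounds shown here, two have been measured in a physicochemical assay for metabolic stability, read by HPLC, in phosphate buffer, at pH 7.4, tested at 10 uM; on this read-out higher numbers stand for a longer-lived compound and lower numbers for a shorter-lived compound. Compound 1 `O=C(c1ccc(Cl)cc1)c1ccc2c(c1)oc(=O)n2C(=O)NCCCCc1ccccc1` gives 4.57 h in this assay. Compound 2 `COc1ccc(-c2ccc3oc(=O)n(C(=O)NCCCCc4ccccc4)c3c2)cc1` gives 2.93 h in this assay, a number that lies within the usual scatter of the value for compound 1. Compound 3 `O=C(NCCCCc1ccccc1)n1c(=O)oc2cc(Br)ccc21` has not yet been measured. Compared with compound 1, it differs in one place: bromo in place of (4-chlorophenyl)carbonyl on an aromatic carbon. Within the data shown here, no measured pair isolates this change, so nothing in the data points to a direction. The step from compound 1 to compound 3 is expected to stay within the scatter, a 1.3-fold lower number from compound 1 to compound 3 (0.12 log units; within the scatter). Compound 3 is therefore estimated at 3.5 h, between 1.5 h and 8 h.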

Compound 3, half-life: 0.4 h
Compound 3: the middle estimate sits 8.8-fold (0.94 log units) above what was measured; measured number below the stated range.
By their numbers in this assay, from the lowest: compound 3; then compounds 2 and 1 (each within the scatter of the next).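

Among these compounds, replacing (4-chlorophenyl)carbonyl with bromo on this aromatic carbon gives an 11-fold lower number from compound 1 to compound 3 (1.06 log units; beyond the scatter) in this assay and is the first step at this position to be seen. It shows that the group on this carbon can move the half-life well beyond the scatter. Nothing measured here says why the number falls.

Whether the aromatic ring, the carbonyl or the chlorine of the departing group accounts for the difference remains open. From the compounds shown here alone, how a plain phenyl, an amine or a carboxylic acid would behave on this carbon also remains open.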